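A few compounds are considered here, and "the series" means these few. Any claim that something is new, unique, unknown or untested is made for them only; others in the source may bear on it.

Measured compounds:
compound 1, `CC1=C[C@H](OC(=O)c2ccc(O)cc2)[C@@H]2[C@](C)(CC[C@@]2(O)C(C)C)CC1=O`, giving 40500 nM in a functional assay on Jurkat cells (Homo sapiens) for cytotoxicity, read by MTT assay, with a stated time of 72 h; a lower number here means a stronger inhibitor, a higher number a weaker inhibitor
compound 2, `CC1=CC[C@]2(C)[C@@H]([C@@H](OC(=O)c3ccc(O)cc3)C1)[C@](O)(C(C)C)C[C@@H]2O`, giving 40300 nM in this assay

Both compounds are esters of the same phenolic acid on closely related bicyclic cores. In this assay compound 1 gives 40500 nM, and compound 2 gives 40300 nM. Compound 2 holds the lower of the two numbers, but its nearest neighbour, compound 1, sits at a gap that lies within the scatter, so the two cannot be set apart. Going by the values given here, no pair of measured compounds differing in a single place has been recorded, so there is no step against which the next change can be calibrated.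

Compound 3, `CC1=CC[C@@]2(C)CC[C@@](O)(C(C)C)[C@@H]2[C@@H](OC(=O)c2ccc(O)cc2)C1`, is still to be measured. Relative to compound 2 the change is hydrogen in place of hydroxy on a saturated ring carbon. Among the compounds with values here, with no measured step to draw on, the expectation for compound 3 is a step from compound 2 of a 1.1-fold higher number from compound 2 to compound 3 (0.05 log units; within the scatter), not clearly beyond the scatter in either direction. Compound 3 is accordingly estimated at 45000 nM, within a range from 15000 nM to 130000 nM.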

Compound 3, half-maximal inhibitory concentration: > 100000 nM
Compound 3: no number, only a limit; the forecaster's own chance of this, stated with the estimate: 25%; middle value at least 2.2-fold (0.34 log units) from the limit.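

In this assay compound 3 gives > 100000 nM, which is a limit of the assay and not a number. Even so, it provides the first comparison here between compounds that differ in one place: hydrogen in place of hydroxy on a saturated ring carbon of the five-membered ring gives an at least 2.4-fold higher number from compound 2 to compound 3 (0.39 log units; beyond the scatter), so this hydroxy cannot be removed without a loss in this assay. The step is only a lower bound, and how far it extends cannot be read from a limit, on which this reading rests: the limit of > 100000 nM in this assay, at which 1 of the 3 values shown sits.

On these data alone, whether a methoxy group, an amine or a fluorine on this same ring carbon would keep the number of compound 2 or lose it as hydrogen does remains open, so the data do not say what about the hydroxy matters here. Also open, as far as these compounds go, is whether the same replacement would have a comparable effect on the core of compound 1, or whether this step holds only on the core shared by compound 2 and compound 3.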